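The source may report more compounds than this note shows. Statements on the series, on what has been measured and on what is new or still open speak of the compounds shown alone.

In a functional assay on KYSE-450 cells (Homo sapiens) for inhibition, read by MTT assay, with a stated time of 48 h (a lower number here means a stronger inhibitor, a higher number a weaker inhibitor), three compounds that share one core and differ only in the group on the carbonyl carbon have been measured. Compound 1 `COc1ccc(CN(C(=O)C(C)Br)c2cc(OC)c(OC)c(OC)c2)cc1O` gives 160 nM, compound 2 `COc1ccc(CN(C(=O)CO)c2cc(OC)c(OC)c(OC)c2)cc1O` gives 370 nM, and compound 3 `COc1ccc(CN(C(=O)CCl)c2cc(OC)c(OC)c(OC)c2)cc1O` gives 210 nM. Compound 3 stands close to both of the others, with a 1.3-fold higher number from compound 1 to compound 3 (0.12 log units; within the scatter) on one side and a 1.8-fold lower number from compound 2 to compound 3 (0.25 log units; within the scatter) on the other. Compound 4 `COc1ccc(CN(C(=O)CN=[N+]=[N-])c2cc(OC)c(OC)c(OC)c2)cc1O` differs from compound 3 by a single change: azido in place of chloro on a saturated chain carbon bound to a carbonyl carbon. In words, this is azido in place of chloro on a saturated chain carbon bound to a carbonyl carbon. Going by the values given here, no measured compound carries azido, so the only guide is the set of replacements at this same place. The largest of them, a 2.3-fold higher number from compound 1 to compound 2 (0.36 log units; beyond the scatter), is still modest, and the other two stay within the scatter. A step within the scatter, with no firm direction, is therefore expected in this assay. The expected change is a 1.1-fold higher number from compound 3 to compound 4 (0.04 log units; within the scatter). For compound 4 the estimated value is 230 nM, with an expected range from 100 nM to 550 nM.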

Compound 4, half-maximal inhibitory concentration: 160 nM
Beside the measured number, compound 4's estimate is 1.4-fold (0.16 log units) above it, within the range that was stated.
By their numbers in this assay, from the lowest: compounds 1, 4, 3 and 2 (each within the scatter of the next, the first and the last beyond it).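

In this assay, azido on a saturated chain carbon bound to a carbonyl carbon cannot be told apart from chloro (a 1.3-fold lower number from compound 3 to compound 4 (0.12 log units; within the scatter)), even though three heavy atoms replace one. Azidomethyl likewise cannot be told apart from 1-bromoethyl on the carbonyl carbon (no change at the digits printed from compound 1 to compound 4 (within the scatter)), while the step from hydroxy to azido lies beyond the scatter but stays modest (a 2.3-fold lower number from compound 2 to compound 4 (0.36 log units; beyond the scatter)), although compound 3 remains within the scatter of compound 2. So this position has now taken a group of a new kind with only small shifts in the number, and no measurement shown gives a reason for these small differences.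

On these data alone, whether an amine or a carboxylic acid on this carbon would stay in the same narrow band remains open. So does the effect of a longer chain in place of azidomethyl.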